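A Hydroxy Group in Place of a Cyano Aryl

This account rests on a few compounds, and the source may have more. Where it says the series, first, only, none or still open, it means among the compounds named here.

Measured in a functional assay (Homo sapiens) for inhibition; a lower number here means a stronger inhibitor, a higher number a weaker inhibitor:
- compound 1 `CCCCOc1ccccc1/C=C/C(=O)c1ccc(OC)c(OC)c1OC`: 52000 nM
- compound 2 `COc1ccc(C(=O)/C=C/c2ccccc2[N+](=O)[O-])c(OC)c1OC`: 7000 nM
- compound 3 `COc1ccc(C(=O)/C=C/c2ccc(C#N)cc2)c(OC)c1OC`: 5400 nM

Compound 3, at 5400 nM, cannot be told apart from compound 2, and both stand clearly under compound 1. The next compound is compound 4 `COc1ccc(C(=O)/C=C/c2ccccc2O)c(OC)c1OC`, which carries 2-hydroxyphenyl in place of 4-cyanophenyl on a double-bonded chain carbon bound to a double-bonded chain carbon.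

For the measured compounds named here, only one measured step exists in this small set, a 7.4-fold lower number from compound 1 to compound 2 (0.87 log units; beyond the scatter). It swaps nitro for butoxy, so it involves neither group at issue here and bears on the change only indirectly, as a guide to size. Going by the values given here, no measured step shows what a hydroxy group does in this assay. A modest rise in the number is therefore expected, of no greater size than that one step, though a result within the scatter would not surprise. The estimate amounts to a 1.9-fold higher number from compound 3 to compound 4 (0.27 log units; within the scatter). Compound 4 is expected at about 10000 nM, with an estimated range from 3000 nM to 35000 nM.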

Compound 4, half-maximal inhibitory concentration: 9000 nM
For compound 4 the middle estimate is 1.1-fold (0.05 log units) above the measured one; low and high end bracket the measured number.
By their numbers in this assay, from the lowest: compounds 3, 2 and 4 (each within the scatter of the next); then compound 1.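

In this assay, 2-hydroxyphenyl in place of 4-cyanophenyl on a double-bonded chain carbon gives a 1.7-fold higher number from compound 3 to compound 4 (0.22 log units; within the scatter) and hydroxy in place of nitro on an aromatic carbon gives a 1.3-fold higher number from compound 2 to compound 4 (0.11 log units; within the scatter), so neither change separates compound 4 from its neighbour. Hydrogen in place of butyl on an oxygen on an aromatic ring, by contrast, gives a 5.8-fold lower number from compound 1 to compound 4 (0.76 log units; beyond the scatter) and sets compound 4 clearly apart from the butoxy compound, as the nitro group does for compound 2. Nothing available bears on the reason for these results.

The compounds shown leave open whether an amine or a carboxylic acid on that aromatic carbon would stay within this range. They also leave open whether methoxy, with its shorter chain, would behave like butoxy or like hydroxy.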